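Swapping the sulfonamide tail for a small nitrogen ring

This account rests on a few compounds, and the source may have more. Where it says the series, first, only, none or still open, it means among the compounds named here.

Measured compounds:
- compound 1, `NS(=O)(=O)CC(=O)NCCSc1nonc1/C(=N/O)Nc1cccc(Cl)c1`: > 3 h
- compound 2, `N#Cc1cccc(N/C(=N\O)c2nonc2SCCNC(=O)CS(N)(=O)=O)c1`: > 3 h
- compound 3, `NS(=O)(=O)CC(=O)NCCSc1nonc1/C(=N/O)Nc1ccc(F)c(C(F)F)c1`: 2.77 h

Of the compounds shown here, three sharing one core have been tested in an ADME assay on microsomes from liver (Homo sapiens) for metabolic stability; on this read-out higher numbers stand for a longer-lived compound and lower numbers for a shorter-lived compound. For compound 1 the assay reports only a limit, > 3 h. For compound 2 the assay likewise reports only a limit, > 3 h. For the measured compounds named here, compound 3 is the single compound with an actual number, 2.77 h; the other two values sit at the limit of > 3 h in this assay, at which 2 of the 3 values shown sit. The steps of an at least 1.0-fold lower number from compound 1 to compound 3 (0.03 log units; that floor lies within the scatter) and an at least 1.0-fold lower number from compound 2 to compound 3 (0.03 log units; that floor lies within the scatter) both change only the aryl group on the amine nitrogen, and both lie within the scatter.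

Compound 4, `CC1(C(=O)NCCSc2nonc2/C(=N/O)Nc2ccc(F)c(C(F)F)c2)CCN1`, differs from compound 3 at the other end of the molecule: a group of 5 heavy atoms (4 carbon, 1 nitrogen; one four-membered non-aromatic ring with 1 hetero atom) in place of a group of 5 heavy atoms (1 carbon, 1 nitrogen, 2 oxygen, 1 sulfur; no ring), on a carbonyl carbon. Going by the values given here, no measured step touches this part of the core, so nothing here shows how this assay responds to such a swap. The expectation therefore rests on compound 3 alone, with a wide range: compound 4 is expected at 2.5 h (between 1.2 h and 5 h), which means an expected step of a 1.1-fold lower number from compound 3 to compound 4 (0.04 log units; within the scatter), not beyond the scatter.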

Compound 4, half-life: 1.97 h
Estimate against measurement, compound 4: 1.3-fold (0.10 log units) above; low and high end bracket the measured number.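

For the compounds shown here, no earlier step touched the group on this carbonyl carbon, and in this assay the swap gives a 1.4-fold lower number from compound 3 to compound 4 (0.15 log units; within the scatter). The sulfamoylmethyl group, with its sulfur and two oxygens, can therefore be replaced by a four-membered non-aromatic ring with one nitrogen, and the result stays within the usual scatter of repeated measurements. This rests on a single pair, so it shows that this one swap leaves the half-life unresolved from that of compound 3, and it sets no rule for the position.

On these data alone, whether other groups on this carbonyl carbon, such as a carboxylic acid or a longer chain ending in an amine, would stay as close remains open. Also open is how the same swap reads with the 3-chlorophenyl or 3-cyanophenyl group, where the starting values are not numbers: the limit of > 3 h in this assay, at which 2 of the 4 values shown sit.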